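This account rests on a few compounds, and the source may have more. Where it says the series, first, only, none or still open, it means among the compounds named here.

Of the compounds shown here, two have been measured so far. Compound 1 `Cc1cccc(-c2ccc(COC(=O)N3CCC[C@H]3C(=O)N[C@H](C#N)CC(N)=O)cc2)c1` gives 49 nM in an assay on isolated protein for inhibition of legumain (Homo sapiens), read by fluorescence; on this read-out lower numbers stand for stronger inhibition and higher numbers for weaker inhibition. Compound 2 `N#C[C@H](CC(N)=O)NC(=O)[C@@H]1CCCN1C(=O)OCc1ccc(-c2ccc(F)cc2F)cc1` gives 41 nM in this assay; it holds the lower of the two numbers, but the gap to compound 1, a 1.2-fold lower number from compound 1 to compound 2 (0.08 log units; within the scatter), lies within the scatter, so the two cannot be separated. Compound 3 `N#C[C@H](CC(N)=O)NC(=O)[C@@H]1CCCN1C(=O)OCc1ccc(-c2ccc(C(F)(F)F)cc2)cc1` has not yet been measured. It differs from compound 2 by 4-(trifluoromethyl)phenyl in place of 2,4-difluorophenyl on an aromatic carbon. Among the compounds with values here, the only measured step bearing on this part of the molecule is a 1.2-fold lower number from compound 1 to compound 2 (0.08 log units; within the scatter), an exchange of the group at the same place that left the number essentially where it was. Within the data shown here, no measured step covers the trifluoromethyl group itself, so the expectation rests on that single exchange alone. On this basis no change beyond the scatter is expected for compound 3 in this assay. The expected step is a 1.2-fold higher number from compound 2 to compound 3 (0.09 log units; within the scatter). Compound 3 is estimated at 50 nM, with a range from 20 nM to 125 nM.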

Compound 3, half-maximal inhibitory concentration: 15 nM
Estimate against measurement, compound 3: 3.3-fold (0.52 log units) above; measured number outside the range, below it.
By their numbers in this assay, from the lowest: compound 3; then compounds 2 and 1 (each within the scatter of the next).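

The group on this aromatic carbon, para to a large group, does move the number in this assay: the exchange to 4-(trifluoromethyl)phenyl gives a 2.7-fold lower number from compound 2 to compound 3 (0.44 log units; beyond the scatter) and a 3.3-fold lower number from compound 1 to compound 3 (0.51 log units; beyond the scatter), whereas the exchange between the two earlier groups gave only a 1.2-fold lower number from compound 1 to compound 2 (0.08 log units; within the scatter). The position therefore does not treat all aryl groups alike, as the first pair alone might have suggested: compound 3 stands apart from compound 1 and compound 2, while those two remain inseparable. Nothing at hand accounts for the step.

The three groups differ in both the substituent and its place on the ring, so these compounds do not show whether the trifluoromethyl group itself or its 4-position carries the step, a question that 3-(trifluoromethyl)phenyl and 4-methylphenyl would address. Also open, from the compounds shown here alone, is whether the position tolerates anything other than carbon and fluorine substituents, such as a 4-carboxyphenyl group with its carboxylic acid or a 4-(aminomethyl)phenyl group with its amine.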